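Chloro-Methylphenyl Triazole Analogue of a Spirooxindole Pair

A few compounds are considered here, and "the series" means these few. Any claim that something is new, unique, unknown or untested is made for them only; others in the source may bear on it.

Two spiro compounds from one series have been tested for antiproliferative activity in a functional assay on HepG2 cells (Homo sapiens) for antiproliferative activity, read by MTT assay, with a stated time of 48 h; a higher number here means a weaker inhibitor, a lower number a stronger inhibitor. Compound 1 `N#CC1=C(N)Oc2c(c3nc4ccccc4nc3c3ccccc23)C12C(=O)N(Cc1cnnn1-c1ccc(Cl)c(Cl)c1)c1ccccc12` gives > 50000 nM, which is a limit of the assay rather than a number. Compound 2 `Cc1ccccc1-n1nncc1CN1C(=O)C2(C(C#N)=C(N)Oc3c(N)cc4nc5ccccc5nc4c32)c2ccccc21` also returns only a limit, > 50000 nM. Both entries therefore sit at the same boundary, as summarised by the limit of > 50000 nM in this assay, at which 2 of the 2 values shown sit, so compound 2 stands no higher or lower than compound 1 on the numbers shown; no ranking between the two is possible.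

Compound 3 `Cc1ccc(-n2nncc2CN2C(=O)C3(C(C#N)=C(N)Oc4c(N)cc5nc6ccccc6nc5c43)c3ccccc32)cc1Cl` has not yet been measured. Its difference from compound 2 is 3-chloro-4-methylphenyl in place of 2-methylphenyl on an aromatic nitrogen. Since both measured compounds sit at the limit, the account expects the change from compound 2 to compound 3 in this assay to be a step that the limit leaves unreadable from compound 2 to compound 3, which is to say no movement beyond the usual scatter. Compound 3 is accordingly estimated at 60000 nM, within a range of 20000 nM to 200000 nM, most likely reported again as a limit.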

Compound 3, half-maximal inhibitory concentration: > 50000 nM
Compound 3: only a limit was reported (the forecaster's own chance of this, stated with the estimate: 80%); the middle value lies beyond the limit too.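

In this assay compound 3 gives > 50000 nM, again a limit of the assay and not a number, so no step can be read from compound 2 to compound 3. The compounds shown leave open whether the group on the aromatic nitrogen changes activity at all, as all entries share one boundary: the limit of > 50000 nM in this assay, at which 3 of the 3 values shown sit.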